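Ester to acid at the lysine-type terminus of compound 2

A few compounds are considered here, and "the series" means these few. Any claim that something is new, unique, unknown or untested is made for them only; others in the source may bear on it.

Three compounds of the series have been run in a functional assay on the whole organism (Tail, strain ICR) with Mus musculus as the target, in the tail flick test, with a stated time of 120 min, at a dose of 25 umol/kg by the oral route; on this read-out lower numbers stand for a weaker effect and higher numbers for a stronger effect at the one dose given. Compound 1 `N=C(N)NCCC[C@H](NC(=O)CN(c1nc(Cl)nc2[nH]cnc12)C1CC1)C(=O)OCc1ccccc1` gives 10.2%. Compound 2 `NCCCC[C@H](NC(=O)CN(c1nc(Cl)nc2[nH]cnc12)C1CC1)C(=O)OCc1ccccc1` gives 16.8%. Compound 3 `C[C@H](NC(=O)CN(c1nc(Cl)nc2[nH]cnc12)C1CC1)C(=O)OCc1ccccc1` gives 36.1%. Compound 2 thus stands second highest of the three numbers; its nearest neighbour is compound 1, and that gap, a number 6.6 percentage points higher from compound 1 to compound 2 (within the scatter), lies within the scatter, so no order between compound 1 and compound 2 is claimed. The gap to compound 3, a number 19.3 percentage points higher from compound 2 to compound 3 (beyond the scatter), lies beyond the scatter, and a number 25.9 percentage points higher from compound 1 to compound 3 (beyond the scatter) points the same way.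

The next compound, compound 4 `NCCCC[C@H](NC(=O)CN(c1nc(Cl)nc2[nH]cnc12)C1CC1)C(=O)O`, keeps the side chain of compound 2 and alters the ester end: hydrogen in place of benzyl on an oxygen next to a carbonyl group. None of the three measured steps touches this part of the molecule; all of them change the substituent on the saturated chain carbon. Among the compounds with values here, no measured step therefore bears directly on the change from compound 2 to compound 4, and no direction can be taken from the data. The expectation is a step of a number 3.8 percentage points lower from compound 2 to compound 4 (within the scatter), that is, nothing beyond the scatter, with a wide range. Compound 4 is estimated at 13%, between 0% and 32%.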

Compound 4, a percentage reported as activity, at one dose (the size of the read-out at that dose, not a potency): 16.4%
The estimate for compound 4 lay 3.4 percentage points below the measured number; measured number inside the range.
By their numbers in this assay, from the lowest: compounds 1, 4 and 2 (each within the scatter of the next); then compound 3.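

Within the data shown here, the ester end, untouched by the earlier steps, is now probed for the first time: in this assay, a number 0.4 percentage points lower from compound 2 to compound 4 (within the scatter), so the benzyl on an oxygen next to a carbonyl group and a hydrogen in its place cannot be told apart with the side chain of compound 2 in the molecule. This contrasts with the change on the saturated chain carbon, where a number 19.3 percentage points higher from compound 2 to compound 3 (beyond the scatter), and it shows that on this side chain, benzyloxycarbonyl to carboxy, with the loss of the six-membered aromatic ring, does not produce a step beyond the scatter. No available evidence bears on this outcome, and the data offer no account of it.

Among these compounds, still open is whether the same exchange would remain within the scatter on the side chains of compound 1 and compound 3, where a carboxy end could give a different picture from the one seen with compound 2. Also open, from the compounds shown here alone, is how smaller esters such as methyl or ethyl, or a primary amide at this end, would read in this assay.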